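The compounds below may be only part of what the source reports. "The series", "measured", "known", "first", "only" and "open" are said of these compounds alone.

The three measured compounds share one core and differ only in the aryl group on the carbon that carries a double bond to nitrogen. Compound 1 `COc1ccccc1-c1nnc(-c2ccc(C(=O)N/N=C/c3cccc(O)c3)cc2)o1` bears a 3-hydroxyphenyl there, and in an ADME assay on THP-1 cells (Homo sapiens) for cytotoxicity (on this read-out lower numbers stand for stronger inhibition and higher numbers for weaker inhibition), compound 1 gives 398000 nM. Compound 2 `COc1ccccc1-c1nnc(-c2ccc(C(=O)N/N=C/c3cccc([N+](=O)[O-])c3)cc2)o1` bears a 3-nitrophenyl, and in this assay compound 2 gives 119000 nM. Compound 3 `COc1ccccc1-c1nnc(-c2ccc(C(=O)N/N=C/c3ccncc3)cc2)o1` bears a pyridin-4-yl, and in this assay compound 3 gives 173000 nM, the second highest of the three numbers. The step of a 1.5-fold higher number from compound 2 to compound 3 (0.16 log units; within the scatter) lies within the scatter, whereas the step of a 2.3-fold lower number from compound 1 to compound 3 (0.36 log units; beyond the scatter) lies beyond it.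

Compound 4 `COc1ccc(/C=N/NC(=O)c2ccc(-c3nnc(-c4ccccc4OC)o3)cc2)cc1O` has not yet been measured. It differs from compound 3 in one place: 3-hydroxy-4-methoxyphenyl in place of pyridin-4-yl on a carbon with a double bond to nitrogen. The measured step that bears on this change is a 2.3-fold lower number from compound 1 to compound 3 (0.36 log units; beyond the scatter), read in the reverse direction, as compound 4 again carries a phenyl with a hydroxy group in the same arrangement as compound 1, now with an added methoxy. Compound 4 is therefore expected to show a modestly higher number, a 1.8-fold higher number from compound 3 to compound 4 (0.27 log units; within the scatter). The estimate for compound 4 in this assay is 320000 nM, with a range from 150000 nM to 650000 nM.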

Compound 4, half-maximal inhibitory concentration: 260000 nM
Beside the measured number, compound 4's estimate is 1.2-fold (0.09 log units) above it; measured number inside the range.
By their numbers in this assay, from the lowest: compounds 2, 3, 4 and 1 (each within the scatter of the next, the first and the last beyond it).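

In this assay, among these compounds, methoxy in place of hydrogen on an aromatic carbon gives a 1.5-fold lower number from compound 1 to compound 4 (0.18 log units; within the scatter) and so adds no change that can be told from the scatter, the first reading of this substitution on a hydroxy-bearing phenyl. The aryl group on the carbon with a double bond to nitrogen also shows a split: 3-hydroxy-4-methoxyphenyl in place of pyridin-4-yl gives a 1.5-fold higher number from compound 3 to compound 4 (0.18 log units; within the scatter) and stays within the scatter, while the same group in place of 3-nitrophenyl gives a 2.2-fold higher number from compound 2 to compound 4 (0.34 log units; beyond the scatter) and lies beyond it. Nothing shown here accounts for either step.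

From the compounds shown here alone, it remains open how an amine or a carboxylic acid would read as the substituent on this phenyl. A longer chain in place of the methoxy is equally untested among these compounds.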